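Swapping Phenoxy for Dimethylamino: What to Expect

A few compounds are considered here, and "the series" means these few. Any claim that something is new, unique, unknown or untested is made for them only; others in the source may bear on it.

Compound 2 `Cc1cc(O)cc(-c2nn(CC#N)cc2-c2ccnc(-c3ccc(Oc4ccccc4)cc3)c2)c1` was tested in a functional assay on OVCAR-8 cells (Homo sapiens) for cytotoxicity, read by sulforhodamine B assay, with a stated time of 48 h, tested at 0.01 uM (a lower number here means a stronger effect, a higher number a weaker effect of the compound at the concentration tested), where compound 2 gives 91%. Among the two measured numbers this is the highest, yet compound 1 `COc1cc(C)cc(-c2c(-c3ccnc(-c4ccc(C(C)=O)cc4)c3)cnn2CC#N)c1`, which in this assay gives 83%, lies within the scatter of it, so no order between the two is claimed. Compound 3 `Cc1cc(O)cc(-c2nn(CC#N)cc2-c2ccnc(-c3ccc(N(C)C)cc3)c2)c1` is not yet measured; it differs from compound 2 by dimethylamino in place of phenoxy on an aromatic carbon. Among the compounds with values here, no measured pair shows this change, so its size in this assay is unknown, and the expected step is small, none beyond the scatter. Compound 3 is therefore estimated at 88%, expected between 70% and 100%. The step this estimate means is a number 3 percentage points lower from compound 2 to compound 3 (within the scatter).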

Compound 3, a percentage reported as activity, at one concentration (the size of the read-out at that concentration, not a potency): 97%
Compound 3: middle estimate off by 9 percentage points, on the low side; measured number inside the range.
By their numbers in this assay, from the lowest: compounds 1, 2 and 3 (each within the scatter of the next, the first and the last beyond it).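

The exchange of phenoxy for dimethylamino, para to a large group, is now measured in this assay as a number 6 percentage points higher from compound 2 to compound 3 (within the scatter). This first measured pair at this position shows that losing the six-membered aromatic ring of phenoxy does not move the read-out beyond the usual scatter at the concentration tested. Nothing measured here bears on the reason for this result. The compounds shown leave open whether a carboxylic acid or a primary amine at this position would separate from compound 2 beyond the scatter.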